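The compounds below may be only part of what the source reports. "The series", "measured", "known", "first", "only" and "open" are said of these compounds alone.

Compound 1, `COc1cccc(C(=O)Oc2cc3c(cc2C)[C@@H](C(C)C)CC=C3C)c1`: in a functional assay on K562 cells (Homo sapiens) for antiproliferative activity, read by sulforhodamine B assay, with a stated time of 48 h, tested at 50 uM (on this read-out higher numbers stand for more inhibition at the one concentration tested (going by the name of the read-out) and lower numbers for less inhibition), compound 1 is reported as "not active" (no number reported).
Compound 2, `CC1=CC[C@H](C(C)C)c2cc(C)c(OC(=O)c3ccc(Cl)cc3)cc21`: 58.9% in this assay.

Compound 2 holds the only number shown; compound 1 offers only a report of inactivity. Compound 3, `COc1ccc(C(=O)Oc2cc3c(cc2C)[C@@H](C(C)C)CC=C3C)cc1`, differs from compound 2 by methoxy in place of chloro on an aromatic carbon. Within the data shown here, no step between two measured compounds is known, so the size of this step can only be expected, not read off. Compound 1 also carries a methoxy and was reported inactive. A drop beyond the scatter is therefore expected for the step of a number 28.9 percentage points lower from compound 2 to compound 3 (beyond the scatter). Compound 3 is expected to give 30%, within 5% to 55%.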

Compound 3, a percentage reported as inhibition, at one concentration (the size of the read-out at that concentration, not a potency): 46.5%
For compound 3 the middle estimate is 16.5 percentage points below the measured one, and the stated range covers the measured number.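

Replacing chloro with methoxy on the aromatic carbon para to a large group gives a number 12.4 percentage points lower from compound 2 to compound 3 (beyond the scatter) in this assay, so inhibition at this position responds to the change but is not lost. The methoxy group alone therefore does not abolish activity: compound 3 gives 46.5%, while compound 1, with its methoxy placed differently, is reported as "not active" (no number reported). Nothing available explains this drop.

From the compounds shown here alone, whether an amine or a hydroxyl at this position would retain inhibition remains open. So does how chloro would fare at the methoxy position of compound 1.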